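Phenyl for allyl at the assay limit

A few compounds are considered here, and "the series" means these few. Any claim that something is new, unique, unknown or untested is made for them only; others in the source may bear on it.

- compound 1 `C=CC/N=C1\S/C(=C\c2ccc(OC)cc2)C(=O)N1C`: > 100000 nM (a limit)
- compound 2 `S=C(Nc1ccccc1)N1C/C(=C/c2ccccc2)S/C1=N\c1ccccc1`: > 100000 nM (a limit)
- compound 3 `COc1ccc(/C=C2/CN(C)/C(=N/c3ccc([N+](=O)[O-])cc3)S2)cc1`: > 100000 nM (a limit)

All three compounds were tested in an ADME assay on TERT-RPE1 cells (Homo sapiens) for cytotoxicity, read by MTT assay, with a stated time of 72 h (on this read-out lower numbers stand for stronger inhibition and higher numbers for weaker inhibition), and none gave an exact number. Compound 1 stands at the limit of > 100000 nM in this assay, at which 3 of the 3 values shown sit (a limit, so it cannot be ranked against the others).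

Compound 4 `COc1ccc(/C=C2\S/C(=N\c3ccccc3)N(C)C2=O)cc1` has not yet been measured. It differs from compound 1 as follows: phenyl in place of allyl on a double-bonded nitrogen. Compound 2 also carries phenyl on a double-bonded nitrogen, and its > 100000 nM is likewise a limit. No step beyond the scatter is expected in this assay in either direction. The expected change is a number no higher from compound 1 to compound 4 (the limit leaves the size open) (an estimate). For compound 4 the estimated value is 100000 nM (expected range 30000 nM to 200000 nM).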

Compound 4, half-maximal inhibitory concentration: > 100000 nM
Compound 4 was reported as a limit; the forecaster's own chance of this, stated with the estimate: 75%; the middle value sits exactly at the limit.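

No step can be read from compound 1 to compound 4, because both results are limits and not numbers: the limit of > 100000 nM in this assay, at which 4 of the 4 values shown sit.

The compounds shown leave open which change in structure, if any, would give an exact number.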